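From cyanocarbamoyl to hydroxy(methyl)carbamoyl on a shared core

A few compounds are considered here, and "the series" means these few. Any claim that something is new, unique, unknown or untested is made for them only; others in the source may bear on it.

In a functional assay on MOLM-13 cells (Homo sapiens) for antiproliferative activity (on this read-out lower numbers stand for stronger inhibition and higher numbers for weaker inhibition), compound 3 `Cc1c(-c2ccc(-c3ccccc3F)cc2)nc2ccc(F)cc2c1C(=O)NC#N` gives > 3000 nM, which is a limit and not a number. Compound 1 `Cc1c(-c2ccc(-c3ccccc3F)cc2)nc2ccc(F)cc2c1C(F)F` gives > 3000 nM, also a limit. Only compound 2 `Cc1c(-c2ccc(-c3ccccc3F)cc2)nc2ccc(F)cc2c1C(O)C(F)(F)F` gives a number, 640 nM. Compound 4 `Cc1c(-c2ccc(-c3ccccc3F)cc2)nc2ccc(F)cc2c1C(=O)N(C)O` carries hydroxy(methyl)amino in place of cyanoamino on a carbonyl carbon.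

Going by the values given here, two measured steps bear on this change, an at least 4.6-fold lower number from compound 1 to compound 2 (0.67 log units; beyond the scatter) and an at least 4.6-fold higher number from compound 2 to compound 3 (0.67 log units; beyond the scatter). Among the compounds with values here, both show that the group at this place can move the read-out, and the second starts from the only true number in the set. A modest fall in the number is therefore expected, though compound 4 may also stay at the limit. The expected step is an at least 2.0-fold lower number from compound 3 to compound 4 (0.30 log units; that floor lies within the scatter). For compound 4 the estimated value is 1500 nM, with an expected range of 400 nM to 5000 nM.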

Compound 4, half-maximal inhibitory concentration: 5100 nM
Compound 4: the middle estimate sits 3.4-fold (0.53 log units) below what was measured, and the stated range ends below it.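

In this assay, going by these compounds alone, compound 4 gives 5100 nM, the first true number for a group joined through a carbonyl carbon at this place. Set against the carbinol, the change gives an 8.0-fold higher number from compound 2 to compound 4 (0.90 log units; beyond the scatter), so hydroxy(methyl)carbamoyl does not match 2,2,2-trifluoro-1-hydroxyethyl here. The steps from compound 1 and from compound 3 to compound 4 cannot be read, because those compounds carry only a limit: the limit of > 3000 nM in this assay, at which 2 of the 4 values shown sit.

Still open, going by these compounds, is whether a carboxylic acid or a simple methylamide on this aromatic carbon would come closer to compound 2. Equally open, on these data alone, is whether a plain hydroxymethyl group would do so.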